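The compounds below may be only part of what the source reports. "The series", "measured", "known", "first", "only" and "open" are said of these compounds alone.

Compound 1 `COc1ccc(/C=C(\C#N)C(=O)Nc2ccccc2OC)cc1`: > 200000 nM, a limit.
Compound 2 `COc1ccccc1NC(=O)/C(C#N)=C/c1ccc(OC)c(OC)c1`: > 200000 nM, a limit.

Both entries come from an ADME assay on HBZY-1 cells (Rattus norvegicus) for cytotoxicity, read by MTT assay, with a stated time of 2 h; a higher number here means a weaker inhibitor, a lower number a stronger inhibitor. Within the data shown here, compound 2 has a limit here and no number, and the series so far stands at the limit of > 200000 nM in this assay, at which 2 of the 2 values shown sit.

Compound 3 `COc1ccccc1NC(=O)/C(C#N)=C/c1cc(OC)c(OC)c(OC)c1` differs from compound 2 by methoxy in place of hydrogen on an aromatic carbon. Among the measured compounds shown here, the one measured step of this kind is a step that the two limits leave unreadable from compound 1 to compound 2, so it offers neither a size nor a direction. Nothing beyond the scatter is expected in this assay, and the expected step is a step that the limit leaves unreadable from compound 2 to compound 3. Compound 3 is estimated at 250000 nM, with an expected range of 100000 nM to 500000 nM. A further limit is the likeliest report.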

Compound 3, half-maximal inhibitory concentration: > 200000 nM
Compound 3 gave a limit, no number; the forecaster's own chance of this, stated with the estimate: 85%; the middle value is on the limit's open side.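

Compound 2 and compound 3 both give limits, not numbers, so no new step can be read between them. Whether methoxy in place of hydrogen on an aromatic carbon changes the read-out at all stays open, with the series standing at: the limit of > 200000 nM in this assay, at which 3 of the 3 values shown sit.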